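A few compounds are considered here, and "the series" means these few. Any claim that something is new, unique, unknown or untested is made for them only; others in the source may bear on it.

In a functional assay on L1210 cells (Mus musculus) for inhibition, with a stated time of 48 h (on this read-out higher numbers stand for weaker inhibition and lower numbers for stronger inhibition), compound 1 (`C=CCOC(=O)N1CCC(C(=O)NCc2ccccc2)(N(Cc2ccccc2)C(=O)[C@H](CC(=O)OC)NC(=O)OC(C)(C)C)CC1`) gives 24000 nM. Compound 2 (`COC(=O)C[C@H](NC(=O)OC(C)(C)C)C(=O)N(Cc1ccc(F)cc1)C1(C(=O)NCc2ccccc2)CCN(Cc2ccccc2)CC1`) gives 22000 nM, which lies within the usual scatter of the value for compound 1, so the two cannot be told apart. Compound 3 (`CCC(C)N(C(=O)[C@H](CC(=O)OC)NC(=O)OC(C)(C)C)C1(C(=O)NCc2ccccc2)CCN(Cc2ccccc2)CC1`) differs from compound 2 in having sec-butyl in place of 4-fluorobenzyl on an amide-type nitrogen. Going by the values given here, no measured step between compounds differing in one place is available as a guide. In this assay, a step no larger than the scatter is expected, with neither direction favoured. Compound 3 is estimated at 25000 nM, with an expected range of 10000 nM to 60000 nM.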

Compound 3, half-maximal inhibitory concentration: 20000 nM
For compound 3 the middle estimate is 1.3-fold (0.10 log units) above the measured one, within the range that was stated.
By their numbers in this assay, from the lowest: compounds 3, 2 and 1 (each within the scatter of the next).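

In this assay, sec-butyl in place of 4-fluorobenzyl on the amide-type nitrogen gives a 1.1-fold lower number from compound 2 to compound 3 (0.04 log units; within the scatter) and so stays within the scatter. At this position, then, the six-membered aromatic ring of carbon only and the fluorine can both leave without a step beyond the scatter, and a branched chain of carbon serves as well as the benzyl group. Nothing at hand bears on why these two compounds read alike.

Still open, going by these compounds, is whether an amine or a carboxylic acid on this nitrogen would read differently. On these data alone, whether a longer chain there would stay within the scatter is equally open.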